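This account rests on a few compounds, and the source may have more. Where it says the series, first, only, none or still open, it means among the compounds named here.

In an ADME assay on Huh-7 cells (Homo sapiens) for cytotoxicity, read by XTT assay (a lower number here means that less compound is tolerated, a higher number that more compound is tolerated), compound 1 `OC[C@@H]1C[C@@H](O)[C@H](n2cnc3c(Cl)ncnc32)O1` reaches only a limit of the assay, > 200000 nM. Compound 2 `O=C(OC[C@@H]1C[C@@H](O)[C@H](n2cnc3c(Cl)ncnc32)O1)c1ccccc1` gives 70500 nM, while compound 3 `CC(C)(C)C(=O)OC[C@H]1O[C@@H](n2cnc3c(Cl)ncnc32)C[C@@H]1O` gives 177000 nM, the higher of the two actual numbers. Compound 4 `Cc1cc(C)c(C(=O)OC[C@H]2O[C@@H](n3cnc4c(Cl)ncnc43)C[C@@H]2O)c(C)c1` differs from compound 3 in one place: 2,4,6-trimethylphenyl in place of tert-butyl on a carbonyl carbon, with 2,4,6-trimethylphenyl in place of tert-butyl on a carbonyl carbon. Going by the values given here, the one measured step that bears on this is an at least 2.8-fold lower number from compound 1 to compound 2 (0.45 log units; beyond the scatter), which adds benzoyl in place of hydrogen on an oxygen on a saturated carbon. Compound 2, at 70500 nM, thus has an aromatic ring on its carbonyl carbon, as compound 4 does, so a lower number is expected. The expected change is a 2.4-fold lower number from compound 3 to compound 4 (0.37 log units; beyond the scatter). Compound 4 is estimated at 75000 nM, with an expected range of 30000 nM to 170000 nM.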

Compound 4, half-maximal cytotoxic concentration: 91000 nM
The estimate for compound 4 lay 1.2-fold (0.08 log units) below the measured number, within the range that was stated.
By their numbers in this assay, from the lowest: compounds 2, 4 and 3 (each within the scatter of the next, the first and the last beyond it). At a limit, above all of these: compound 1.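

In this assay, putting 2,4,6-trimethylphenyl in place of tert-butyl on the carbonyl carbon gives a 1.9-fold lower number from compound 3 to compound 4 (0.29 log units; within the scatter), so this exchange cannot be told apart from repeat-measurement noise. At this position, then, a six-membered aromatic ring and a group with no ring are not separated in this assay, even though the entering group has more heavy atoms. Nothing measured here offers an explanation for this result. This rests on a single pair of compounds. From the compounds shown here alone, whether a longer chain, an amine or a carboxylic acid on this carbonyl carbon would also stay within the scatter of compound 3 remains open.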